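The source may hold more compounds than are shown below. What is called first, only, known or untested is meant among the compounds shown, and "the series" means these compounds.

Measured in a functional assay on SW480 cells (Homo sapiens) for inhibition, read by luminescence and resazurin assay, with a stated time of 3 days; a higher number here means a weaker inhibitor, a lower number a stronger inhibitor:
- compound 1 `CNc1nc(NCc2ccc(C(=O)NC3CCN(Cc4ccc(F)cc4)CC3)cc2)c2cc(C)ccc2n1`: 1300 nM
- compound 2 `Cc1ccc2nc(N(C)C)nc(NCc3ccc(C(=O)NC4CCN(Cc5ccc(F)cc5)CC4)cc3)c2c1`: 1100 nM

Compound 2 cannot be separated from compound 1 on these numbers. Among the measured compounds shown here, the only measured step, a 1.2-fold lower number from compound 1 to compound 2 (0.07 log units; within the scatter), lies within the scatter. Compound 3 `Cc1ccc2nc(N3CCNC(C)C3)nc(NCc3ccc(C(=O)NC4CCN(Cc5ccc(F)cc5)CC4)cc3)c2c1` keeps the rest of compound 2 and carries 3-methylpiperazin-1-yl in place of dimethylamino on an aromatic carbon, between two ring nitrogen atoms: 3-methylpiperazin-1-yl in place of dimethylamino on an aromatic carbon. The measured step changed the same substituent, but only by a methyl in place of hydrogen, so it is a weak guide to a change of this size. For the measured compounds named here, no measured compound carries a ring at this place. Going by the values given here, with only that small step to go on, no step beyond the scatter is expected in this assay, and the range is kept wide. The estimated step is a 1.4-fold lower number from compound 2 to compound 3 (0.14 log units; within the scatter). The estimate for compound 3 is 800 nM, with an expected range of 250 nM to 2500 nM.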

Compound 3, half-maximal inhibitory concentration: 1000 nM
Beside the measured number, compound 3's estimate is 1.3-fold (0.10 log units) below it, and the stated range covers the measured number.
By their numbers in this assay, from the lowest: compounds 3, 2 and 1 (each within the scatter of the next).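

In this assay, the change to 3-methylpiperazin-1-yl, the first ring at this aromatic carbon, gives a 1.1-fold lower number from compound 2 to compound 3 (0.04 log units; within the scatter) and, set against methylamino, a 1.3-fold lower number from compound 1 to compound 3 (0.11 log units; within the scatter) as a step of the same kind. The position between two ring nitrogen atoms therefore accepts a six-membered non-aromatic ring with 2 hetero atoms and a hydrogen-bond donor with no step beyond the scatter, which the earlier methyl step alone could not show. No evidence is available to explain this result.

From the compounds shown here alone, whether a morpholine ring, a plain amino group or a carboxylic acid-bearing chain at this carbon would give a step beyond the scatter remains open. Going by these compounds, the contribution of the ring methyl, set against plain piperazin-1-yl, also remains open.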